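This account rests on a few compounds, and the source may have more. Where it says the series, first, only, none or still open, it means among the compounds named here.

Measured compounds and their values in a functional assay on ECa-109 cells for inhibition, with ECa-109 cell line (Homo sapiens) as the target, read by sulforhodamine B assay; a higher number here means a weaker inhibitor, a lower number a stronger inhibitor:
- compound 1 `O=C1C(Nc2cccc(Cl)c2)=CC(=O)c2c1nc1n2[C@H]2OC[C@@H](O)[C@H]2OC1` gives 3080 nM
- compound 2 `CCc1ccc(NC2=CC(=O)c3nc4n(c3C2=O)[C@H]2OC[C@@H](O)[C@H]2OC4)cc1` gives 3080 nM
- compound 3 `O=C1C=C(NC2CCCCC2)C(=O)c2c1nc1n2[C@H]2OC[C@@H](O)[C@H]2OC1` gives > 16000 nM, which is a limit of this assay rather than a number

Compound 1 and compound 2 stand level with one another at the digits shown, both carrying an aromatic ring directly on the amine nitrogen. Compound 3 is known only as a limit (the limit of > 16000 nM in this assay, at which 1 of the 3 values shown sits), so its true value is not pinned down. Compound 4 `O=C1C(NCc2ccccc2)=CC(=O)c2c1nc1n2[C@H]2OC[C@@H](O)[C@H]2OC1` is the compound to be measured, and it differs from compound 1 by benzyl in place of 3-chlorophenyl on an amine nitrogen.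

Among the compounds with values here, the one measured step that bears on this change is an at least 5.1-fold higher number from compound 2 to compound 3 (0.71 log units; beyond the scatter), where a saturated ring replaced an aromatic one on the same nitrogen and the number rose beyond the scatter. A benzyl group keeps the aromatic ring but moves it one carbon away from the nitrogen, so compound 4 sits between the two measured cases. A weakening in this assay is therefore expected, though smaller than the step to compound 3, and the expected step is a 2.6-fold higher number from compound 1 to compound 4 (0.41 log units; beyond the scatter). Compound 4 is estimated at 8000 nM, with a plausible range from 3000 nM to 20000 nM.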

Compound 4, half-maximal inhibitory concentration: > 8000 nM
Compound 4 was reported as a limit; the forecaster's own chance of this, stated with the estimate: 35%; the middle value lies on the limit itself.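

In this assay, an aromatic ring alone does not keep the number low at this amine nitrogen: benzyl still carries the aromatic ring, yet it gives an at least 2.5-fold higher number from compound 1 to compound 4 (0.41 log units; beyond the scatter). The earlier step, an at least 5.1-fold higher number from compound 2 to compound 3 (0.71 log units; beyond the scatter), replaced the aromatic ring with a saturated one, so it could not show whether the ring itself or its direct attachment to the nitrogen mattered; among the four compounds, only compound 1 and compound 2 have the ring directly on the nitrogen, and only they give numbers rather than limits. Compound 4 is known only as a limit, so the full size of its step stays unknown: the limit of > 8000 nM in this assay, at which 1 of the 4 values shown sits.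

The change to benzyl both adds a carbon link and removes the chlorine, so the compounds shown cannot separate the two, and a 3-chlorobenzyl group or an unsubstituted phenyl group on the same nitrogen would be needed to do so. As far as these compounds go, with compound 3 and compound 4 both known only as limits, their order also stays open, as does the effect of a longer chain such as 2-phenylethyl.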